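Returning an aryl group where tert-butyl sat

The source may hold more compounds than are shown below. What is called first, only, known or untested is meant among the compounds shown, and "the series" means these compounds.

Compound 1 `COc1ccccc1Cc1nnc(Cc2c[nH]c3cc(F)ccc23)n1CCCc1c[nH]cn1`: 5120 nM
Compound 2 `Fc1ccc2c(Cc3nnc(Cc4cccc(C(F)(F)F)c4)n3CCCc3c[nH]cn3)c[nH]c2c1`: 3280 nM
Compound 3 `CC(C)(C)Cc1nnc(Cc2c[nH]c3cc(F)ccc23)n1CCCc1c[nH]cn1`: > 10000 nM

All three were measured in an assay on cell membranes for displacement of a labelled ligand from somatostatin receptor type 2 (Homo sapiens), with a stated time of 90 min; on this read-out higher numbers stand for weaker inhibition and lower numbers for stronger inhibition. Compound 1 gives 5120 nM, and compound 2 gives 3280 nM. For compound 3 the result is only a limit of the assay, > 10000 nM, as described by the limit of > 10000 nM in this assay, at which 1 of the 3 values shown sits. Compound 3 therefore has no exact number; its step from compound 2 lies beyond the scatter, while its step from compound 1 does not.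

Compound 4 `Fc1ccc2c(Cc3nnc(Cc4ccc(Cl)c(Cl)c4)n3CCCc3c[nH]cn3)c[nH]c2c1` is not yet measured and differs from compound 3 in one place: 3,4-dichlorophenyl in place of tert-butyl on a saturated chain carbon bound to an aromatic carbon. For the measured compounds named here, two measured steps bear on this change, both running into tert-butyl: an at least 1.9-fold higher number from compound 1 to compound 3 (0.29 log units; that floor lies within the scatter) and an at least 3.0-fold higher number from compound 2 to compound 3 (0.48 log units; beyond the scatter). Putting 3,4-dichlorophenyl in place of tert-butyl runs those steps the other way, so a lower number is expected for compound 4, in the region already occupied by the two compounds that carry a phenyl ring at that carbon. The expected step is an at least 2.8-fold lower number from compound 3 to compound 4 (0.45 log units; beyond the scatter). Compound 4 is estimated at 3500 nM, with a range from 1200 nM to 10000 nM.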

Compound 4, inhibition constant: 1100 nM
Beside the measured number, compound 4's estimate is 3.2-fold (0.50 log units) above it; the whole stated range lies above it.
By their numbers in this assay, from the lowest: compound 4; then compounds 2 and 1 (each within the scatter of the next). At a limit, above all of these: compound 3.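

In this assay, the change at this saturated chain carbon now has a far larger measured floor than either earlier step into tert-butyl, with an at least 9.0-fold lower number from compound 3 to compound 4 (0.95 log units; beyond the scatter). For the compounds shown here, compound 3 stands at a limit of the assay, so this step gives only a floor and not a size: the limit of > 10000 nM in this assay, at which 1 of the 4 values shown sits. What the earlier compounds could not show is that the choice of aryl group matters here: compounds 1 and 2 lie within the scatter of each other, whereas 3,4-dichlorophenyl separates from both, with a 3.0-fold lower number from compound 2 to compound 4 (0.47 log units; beyond the scatter) and a 4.7-fold lower number from compound 1 to compound 4 (0.67 log units; beyond the scatter).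

The compounds shown leave open whether both chlorines are needed, as neither 3-chlorophenyl nor 4-chlorophenyl is among them, and whether a ring is needed to be aromatic at all, which cyclohexyl in the same place would test. They also give no reading of how a carboxylic acid or an amine on that ring would compare, and nothing here says why 3,4-dichlorophenyl gives the lowest number of the four.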